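Aryl swap on the ring nitrogen of the shared core

A few compounds are considered here, and "the series" means these few. Any claim that something is new, unique, unknown or untested is made for them only; others in the source may bear on it.

For the measured compounds named here, compound 2 `COc1cc2c(Oc3ccc(NC(=O)c4nn(-c5ccccc5Br)c(=O)c5ccccc45)cc3F)ccnc2cc1OCCCN1CCCC1` gives 850 nM in a functional assay on HT-29 cells (Homo sapiens) for cytotoxicity, read by MTT assay, with a stated time of 72 h (a lower number here means a stronger inhibitor, a higher number a weaker inhibitor), the highest of the two numbers so far; its nearest neighbour, compound 1 `COc1cc2c(Oc3ccc(NC(=O)c4nn(-c5ccccc5F)c(=O)c5ccccc45)cc3F)ccnc2cc1OCCCN1CCCC1`, gives 400 nM. Going by the values given here, the only measured step, a 2.1-fold higher number from compound 1 to compound 2 (0.33 log units; beyond the scatter), concerns the same phenyl group on the ring nitrogen that is now changed again. Compound 3 `COc1ccc(-n2nc(C(=O)Nc3ccc(Oc4ccnc5cc(OCCCN6CCCC6)c(OC)cc45)c(F)c3)c3ccccc3c2=O)cc1` differs from compound 2 by 4-methoxyphenyl in place of 2-bromophenyl on an aromatic nitrogen. Among the compounds with values here, that one step bears on it only loosely: it shows that exchanging the single substituent on this phenyl moves this assay modestly, but no measured pair covers a methoxy group on this phenyl, so the direction stays open. A step near or within the scatter is expected, a 1.4-fold lower number from compound 2 to compound 3 (0.15 log units; within the scatter), with the number for compound 3 expected to settle close to where the two measured compounds sit. For compound 3 the estimate in this assay is 600 nM, with a range of 200 nM to 1800 nM.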

Compound 3, half-maximal inhibitory concentration: 2360 nM
Estimate against measurement, compound 3: 3.9-fold (0.59 log units) below; measured number above the stated range.
By their numbers in this assay, from the lowest: compound 1; then compound 2; then compound 3.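

With 4-methoxyphenyl on the ring nitrogen, the number in this assay rises further than the halogen exchange alone had shown, with a 2.8-fold higher number from compound 2 to compound 3 (0.44 log units; beyond the scatter) and a 5.9-fold higher number from compound 1 to compound 3 (0.77 log units; beyond the scatter) as the two steps. This position therefore tolerates less than the first pair suggested, and among the three compounds, compound 3 is the weakest inhibitor, with its steps from both halogenated compounds beyond the scatter. No supporting data bear on why the number rises.

As far as these compounds go, the change replaces the substituent and alters its place on the phenyl in a single step, so whether the rise follows the methoxy group or its place stays open. Also open, from the compounds shown here alone, is how this assay would read with an unsubstituted phenyl, or with a carboxylic acid or an amine on the phenyl.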